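A few compounds are considered here, and "the series" means these few. Any claim that something is new, unique, unknown or untested is made for them only; others in the source may bear on it.

Measured compounds:
Compound 1, `COc1ccc(C(=O)c2sc(NC(C)C)c(C#N)c2N)cc1`, in an assay for inhibition of Maternal embryonic leucine zipper kinase (Homo sapiens), read by ADP-Glo, with a stated time of 0.5 h (on this read-out higher numbers stand for weaker inhibition and lower numbers for stronger inhibition), gives 4130 nM.
Compound 2, `CC(C)Nc1sc(C(=O)c2cccnc2)c(N)c1C#N`, in this assay gives > 5000 nM, which is a limit of the assay rather than a number.

Both measured compounds share one core carrying an amino group, a nitrile and an isopropylamino group, and they differ only in the aromatic ring joined to the carbonyl. Compound 1 gives a real number. Compound 2 stands at the limit of > 5000 nM in this assay, at which 1 of the 2 values shown sits, so its true position is not pinned down. No step between two measured compounds is shown here, so no measured change of ring can serve as a yardstick.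

Compound 3, `CC(C)Nc1sc(C(=O)c2cc(Br)cs2)c(N)c1C#N`, is still to be measured in this assay. Within the data shown here, its one change from compound 2 is 4-bromothiophen-2-yl in place of pyridin-3-yl on a carbonyl carbon. With compound 2 sitting only at a limit, the step from compound 2 to compound 3 is expected to be small and uncertain in direction, roughly a number no higher from compound 2 to compound 3 (the limit leaves the size open), and possibly no more than the scatter. Compound 3 is estimated to give around 5000 nM in this assay, with a plausible range from 1500 nM to 15000 nM.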

Compound 3, half-maximal inhibitory concentration: 599 nM
Beside the measured number, compound 3's estimate is 8.3-fold (0.92 log units) above it; measured number outside the range, below it.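

The ring on this carbonyl carbon can shift the result by a clear margin: in this assay, 4-bromothiophen-2-yl in place of pyridin-3-yl gives an at least 8.3-fold lower number from compound 2 to compound 3 (0.92 log units; beyond the scatter). With the same shared core, compound 1 gives 4130 nM and compound 3 gives 599 nM, so the series now has two real numbers rather than one, each with a different ring at this position. The value of compound 2 is a limit and not a number, so this step fixes only a minimum size: the limit of > 5000 nM in this assay, at which 1 of the 3 values shown sits.

The new ring and its bromine arrive together, so the compounds shown cannot tell whether the lower number comes from the five-membered sulfur ring, from the bromine, or from both, and a plain thiophen-2-yl ring or a chlorine in place of the bromine would be needed to separate them. They also say nothing about the other parts of the core, for example what a longer chain in place of the isopropyl group on the amino nitrogen would do to the number.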